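Swapping the sulfonamide-side benzyloxy for a chlorinated aryl

This account rests on a few compounds, and the source may have more. Where it says the series, first, only, none or still open, it means among the compounds named here.

Compound 2 `O=C1c2ccccc2N(COCc2ccccc2)S(=O)(=O)N1COCc1ccccc1` is the reference point. Within the data shown here, in a functional assay on CCRF-CEM cells (Homo sapiens) for inhibition (a higher number here means that more compound is tolerated, a lower number that less compound is tolerated), compound 2 gives 27700 nM, the higher of the two numbers measured so far; the only other measured compound, compound 1 `O=C1c2ccccc2N(COCc2ccccc2)S(=O)(=O)N1Cc1ccccc1`, gives 25000 nM, and the step of a 1.1-fold higher number from compound 1 to compound 2 (0.04 log units; within the scatter) shows the two lie within the scatter of each other.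

Compound 3 `O=C1c2ccccc2N(Cc2ccccc2Cl)S(=O)(=O)N1COCc1ccccc1` has not been measured. It differs from compound 2 in one place: 2-chlorophenyl in place of benzyloxy on a saturated chain carbon bound to a sulfonamide nitrogen in a ring. Among the measured compounds shown here, the one measured step that speaks to this kind of exchange is a 1.1-fold higher number from compound 1 to compound 2 (0.04 log units; within the scatter), where a phenyl-to-benzyloxy swap on the saturated chain carbon at the amide-type nitrogen changed nothing beyond the scatter. For the measured compounds named here, that step concerns the other nitrogen of the shared core, and no measured compound carries a chlorine, so the evidence is indirect.

On that basis the step of a 1.3-fold lower number from compound 2 to compound 3 (0.10 log units; within the scatter) is expected to stay within the scatter. Compound 3 is therefore estimated at 22000 nM in this assay, within a range from 7000 nM to 70000 nM.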

Compound 3, half-maximal cytotoxic concentration: 22200 nM
Estimate against measurement, compound 3: 1.0-fold (0.00 log units) below; the measured number falls inside the stated range.
By their numbers in this assay, from the lowest: compounds 3, 1 and 2 (each within the scatter of the next).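

The exchange of (benzyloxy)methyl for 2-chlorobenzyl gives the only step shown on a saturated chain carbon bound to a sulfonamide nitrogen in a ring, whereas compound 1 and compound 2 differ only at the amide-type nitrogen. In this assay this change reads as a 1.2-fold lower number from compound 2 to compound 3 (0.10 log units; within the scatter), so the number at this position stays within the scatter even though the ether oxygen leaves, the hydrogen-bond acceptor count of the group falls from 1 to 0, and a chlorine enters on the aromatic ring. Nothing available here explains why the number holds steady across this change.

Because the oxygen and the chlorine change together, the compounds shown cannot separate the contribution of either, and a plain benzyl group at this position would be needed to pull them apart. From the compounds shown here alone, it also remains open whether a group of a different kind on this carbon, such as an amine, a carboxylic acid or a longer chain, would carry the number beyond the scatter.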